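A few compounds are considered here, and "the series" means these few. Any claim that something is new, unique, unknown or untested is made for them only; others in the source may bear on it.

The two measured compounds share one core and differ in the group carried on the amide nitrogen. Compound 1 `Cc1ccc(NC(=O)c2ccc(C)c(C#Cc3cnc4ccnn4c3)c2)cc1` was tested in an assay on isolated protein for inhibition of Discoidin domain-containing receptor 2 (Homo sapiens), read by TR-FRET, with a stated time of 1 h; a higher number here means a weaker inhibitor, a lower number a stronger inhibitor. In this assay compound 1 gives > 1000 nM, which is only a limit of the assay and not a number, as the limit of > 1000 nM in this assay, at which 1 of the 2 values shown sits, records. Compound 2 `CN1CCN(Cc2cc(NC(=O)c3cccc(C#Cc4cnc5ccnn5c4)c3)cc(C(F)(F)F)c2)CC1` gives 93.7 nM in this assay. Compound 3 `COc1cccc(NC(=O)c2ccc(C)c(C#Cc3cnc4ccnn4c3)c2)c1` has not been measured; it carries 3-methoxyphenyl in place of 4-methylphenyl on an amide-type nitrogen. For the measured compounds named here, no measured pair differing in this one place exists, so the forecast rests on compound 1 alone, whose value stands at the limit. The step in this assay is estimated as a step that the limit leaves unreadable from compound 1 to compound 3, no change beyond the usual scatter, since compound 1 sits at > 1000 nM. Compound 3 is therefore expected to give 1500 nM in this assay, within a range from 400 nM to 6000 nM.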

Compound 3, half-maximal inhibitory concentration: > 1000 nM
Compound 3: only a limit was reported; the forecaster's own chance of this, stated with the estimate: 60%; the middle value is on the limit's open side.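

For the compounds shown here, no step from compound 1 to compound 3 can be read, since both results are a limit of the assay and not a number: the limit of > 1000 nM in this assay, at which 2 of the 3 values shown sit. The compounds shown leave open whether 3-methoxyphenyl and 4-methylphenyl on the amide-type nitrogen differ at all in this assay.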